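The compounds below may be only part of what the source reports. "The series", "measured", "known", "first", "only" and "open" are said of these compounds alone.

Values in a functional assay on MX1 cells (Homo sapiens) for inhibition, read by MTT assay, with a stated time of 120 h; a higher number here means a weaker inhibitor, a lower number a stronger inhibitor:
- compound 1 `CC(NC(=O)c1cccc(-c2ccc(NC(=O)Nc3ccc(Cl)c(C(F)(F)F)c3)cc2)c1)c1ccccc1`: 5240 nM
- compound 2 `CNC(=O)/C=C/c1ccc(NC(=O)Nc2ccc(Cl)c(C(F)(F)F)c2)cc1`: 13800 nM
- compound 3 `CC1CN(C(=O)/C=C/c2ccc(NC(=O)Nc3ccc(Cl)c(C(F)(F)F)c3)cc2)CC(C)O1`: 12800 nM

Compound 2 lies at the high end of these three numbers, while compound 1 is lower at 5240 nM. Compound 4 `CNC(=O)CCc1ccc(NC(=O)Nc2ccc(Cl)c(C(F)(F)F)c2)cc1` differs from compound 2 as follows: 2-(methylcarbamoyl)ethyl in place of 2-(methylcarbamoyl)ethenyl on an aromatic carbon. In words, 2-(methylcarbamoyl)ethyl stands in place of 2-(methylcarbamoyl)ethenyl on an aromatic carbon. Among the compounds with values here, the one measured step, a 1.1-fold lower number from compound 2 to compound 3 (0.03 log units; within the scatter), changes the group on the carbonyl carbon, so it bears only indirectly on this change. Within the data shown here, no measured step tests this change itself, so no step beyond the scatter is expected in this assay. The expected step is a 1.0-fold higher number from compound 2 to compound 4 (0.01 log units; within the scatter). Compound 4 is estimated at 14000 nM, with an expected range of 6500 nM to 30000 nM.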

Compound 4, half-maximal inhibitory concentration: 20400 nM
Compound 4: middle estimate off by 1.5-fold (0.16 log units), on the low side, and the stated range covers the measured number.
By their numbers in this assay, from the lowest: compound 1; then compounds 3, 2 and 4 (each within the scatter of the next).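

In this assay, the position para to a large group tolerates loss of the chain's double bond: 2-(methylcarbamoyl)ethyl in place of 2-(methylcarbamoyl)ethenyl gives a 1.5-fold higher number from compound 2 to compound 4 (0.17 log units; within the scatter), so this pair shows no measurable dependence on that double bond. The earlier step changed only the group on the carbonyl carbon, whereas this one tests the chain itself. Nothing available accounts for this result.

Still open, as far as these compounds go, is how a longer chain on this aromatic carbon would read in this assay, or a carboxylic acid or an amine at the end of the chain.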